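Methoxy for bromo on the aryl ring of compound 2

The source may hold more compounds than are shown below. What is called first, only, known or untested is meant among the compounds shown, and "the series" means these compounds.

The account concerns two measured compounds and one whose number is still to come. Compound 1, `CNC(=O)c1cc(Oc2ccc(NC(=O)c3cc4cccnc4n(-c4ccc(OC)cc4)c3=O)cc2)ccn1`, gives 920 nM in a functional assay on HT-29 cells (Homo sapiens) for antiproliferative activity, read by MTT assay, with a stated time of 72 h; on this read-out lower numbers stand for stronger inhibition and higher numbers for weaker inhibition. Compound 2, `CCNC(=O)c1cc(Oc2ccc(NC(=O)c3cc4cccnc4n(-c4ccc(Br)cc4)c3=O)cc2)ccn1`, gives 1160 nM in this assay, which is the higher of the two numbers, though the gap to compound 1 lies within the scatter, so no order between them is claimed. Compound 3, `CCNC(=O)c1cc(Oc2ccc(NC(=O)c3cc4cccnc4n(-c4ccc(OC)cc4)c3=O)cc2)ccn1`, has not yet been measured in this assay. It differs from compound 2 in one place: methoxy in place of bromo on an aromatic carbon. Within the data shown here, no step between measured compounds joins these two. Since compound 1 also carries the methoxy and gives 920 nM, the step of a 1.2-fold lower number from compound 2 to compound 3 (0.09 log units; within the scatter) is expected to be small, with no direction beyond the scatter. Compound 3 is therefore estimated at 950 nM in this assay, within a range from 450 nM to 2000 nM.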

Compound 3, half-maximal inhibitory concentration: 3350 nM
Compound 3: the middle estimate sits 3.5-fold (0.55 log units) below what was measured, outside the stated range (above it).
By their numbers in this assay, from the lowest: compounds 1 and 2 (each within the scatter of the next); then compound 3.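

With the amide chain held fixed, the change from 4-bromophenyl to 4-methoxyphenyl gives a 2.9-fold higher number from compound 2 to compound 3 (0.46 log units; beyond the scatter) in this assay, so this para substituent registers in the read-out, which the earlier pair could not show, since compound 1 and compound 2 differ in two places. With the methoxy held fixed, methyl in place of hydrogen on the saturated chain carbon bound to the amide nitrogen gives a 3.6-fold higher number from compound 1 to compound 3 (0.56 log units; beyond the scatter), so the amide chain also registers. Nothing measured here accounts for either step.

Going by these compounds, whether the bromo and methoxy step keeps its size and direction on the shorter amide chain stays open. Also open, on these data alone, is where chloro or an amine on the aryl ring, or a propyl chain on the amide, would fall relative to compound 2 and compound 3.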